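Chloro to methyl on the fused core of compound 2

The compounds below may be only part of what the source reports. "The series", "measured", "known", "first", "only" and "open" are said of these compounds alone.

Of the compounds shown here, two have been measured in a functional assay on cells for agonist activity at Free fatty acid receptor 1 (Homo sapiens), read by FLIPR and calcium flux; on this read-out higher numbers stand for an effect only at larger amounts of compound and lower numbers for an effect already at smaller amounts. Compound 1 `CC#C[C@@H](Cc1nnn[nH]1)c1ccc(OCc2ccc3scc(-c4cc(OCCOC)ccc4C)c3c2)cc1` gives 85 nM. Compound 2 `CC#C[C@@H](Cc1nnn[nH]1)c1ccc(OCc2cc(Cl)c3scc(-c4ccccc4C)c3c2)cc1` gives 63 nM in this assay. Compound 2 stands together with compound 1: the two numbers lie within the scatter of each other, so neither stands apart.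

Compound 3 `CC#C[C@@H](Cc1nnn[nH]1)c1ccc(OCc2cc(C)c3scc(-c4ccccc4C)c3c2)cc1` has not yet been measured. It differs from compound 2 in one place: methyl in place of chloro on an aromatic carbon. Among the compounds with values here, no measured pair shows the effect of this change, and the replacement keeps the count of heavy atoms the same, with no donor or acceptor added or removed.

No step beyond the scatter is expected in this assay, so the step from compound 2 to compound 3 is estimated at a 1.1-fold higher number from compound 2 to compound 3 (0.05 log units; within the scatter). Because compound 2 gives 63 nM in this assay, compound 3 is expected near 70 nM, with a range from 30 nM to 160 nM.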

Compound 3, half-maximal effective concentration: 134 nM
Beside the measured number, compound 3's estimate is 1.9-fold (0.28 log units) below it; measured number inside the range.
By their numbers in this assay, from the lowest: compounds 2, 1 and 3 (each within the scatter of the next, the first and the last beyond it).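

In this assay, within the data shown here, methyl in place of chloro on this aromatic carbon gives a 2.1-fold higher number from compound 2 to compound 3 (0.33 log units; beyond the scatter), the first single-place step and a modest one. The position therefore responds to this change, even though the heavy-atom count stays the same and no hydrogen-bond donor or acceptor enters or leaves. Nothing at hand accounts for the step, so no cause can be assigned to it.

As far as these compounds go, whether fluoro, methoxy, nitrile or plain hydrogen on this carbon would give a number nearer that of compound 2 or that of compound 3 remains open. Also open, from the compounds shown here alone, is whether the same change would give a similar step on the core of compound 1, which differs from compound 2 and compound 3 in more than one place.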